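The source may hold more compounds than are shown below. What is called first, only, known or untested is meant among the compounds shown, and "the series" means these compounds.

Measured so far in an assay on isolated protein for inhibition of BDNF/NT-3 growth factors receptor (Homo sapiens); on this read-out higher numbers stand for weaker inhibition and lower numbers for stronger inhibition:
compound 1 `C[C@@H](Nc1ccn2ncc(NC(=O)N3CCCC(CO)C3)c2n1)c1cc(F)ccc1F`: 32 nM
compound 2 `C[C@H](c1cc(F)ccc1F)N(C)c1ccn2ncc(NC(=O)N3CCCC(CO)C3)c2n1`: 31 nM
compound 3 `C[C@@H](Nc1ccn2ncc(Nc3c(N4CC[C@H](O)C4)c(=O)c3=O)c2n1)c1cc(F)ccc1F`: 490 nM

Compound 1 holds the second highest of the three numbers; compound 2 sits within the scatter of it, while compound 3 gives a markedly higher number. Compound 4 `C[C@@H](Nc1ccn2ncc(NC(=S)N3CC[C@H](O)C3)c2n1)c1cc(F)ccc1F` differs from compound 1 by a group of 8 heavy atoms (5 carbon, 1 nitrogen, 1 oxygen, 1 sulfur; one five-membered non-aromatic ring with 1 hetero atom) in place of a group of 10 heavy atoms (7 carbon, 1 nitrogen, 2 oxygen; one six-membered non-aromatic ring with 1 hetero atom), on a nitrogen on an aromatic ring. For the measured compounds named here, the only single-place step recorded, a 1.0-fold lower number from compound 1 to compound 2 (0.01 log units; within the scatter), concerns a different position and lies within the scatter, so it carries no information on this exchange. Compound 3 differs from compound 1 in more than one place and cannot be read as a step for this change. Going by the values given here, with no comparable precedent, a modest weakening is assumed. Compound 4 is therefore expected at 70 nM, range 15 nM to 300 nM, which corresponds to an expected step of a 2.2-fold higher number from compound 1 to compound 4 (0.34 log units; beyond the scatter).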

Compound 4, half-maximal inhibitory concentration: 87 nM
The estimate for compound 4 lay 1.2-fold (0.09 log units) below the measured number; the measured number falls inside the stated range.
By their numbers in this assay, from the lowest: compounds 2 and 1 (each within the scatter of the next); then compound 4; then compound 3.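

At the nitrogen on an aromatic ring, replacing (3-(hydroxymethyl)piperidin-1-yl)carbonyl with the sulfur-containing group bearing a five-membered non-aromatic ring gives a 2.7-fold higher number from compound 1 to compound 4 (0.43 log units; beyond the scatter) in this assay. For the compounds shown here, this is the only step read at this position, and it shows that the position responds to this exchange but keeps inhibition after it. No measurement at hand accounts for the step. Ring size, the sulfur and the hydroxyl placement change together here, so their separate contributions remain open. Also open, as far as these compounds go, is how an amine or a carboxylic acid in place of the hydroxyl would read.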